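Methyl in place of methoxy: notes on compound 4

A few compounds are considered here, and "the series" means these few. Any claim that something is new, unique, unknown or untested is made for them only; others in the source may bear on it.

In a functional assay on MCF7 cells (Homo sapiens) for antiproliferative activity, read by MTT assay, with a stated time of 72 h (on this read-out higher numbers stand for weaker inhibition and lower numbers for stronger inhibition), compound 1 (`COc1ccc(N2C(=O)COc3ccc(-c4cnc(Cl)c(NS(=O)(=O)c5ccc(F)cc5)c4)cc32)cc1`) gives 36000 nM as the higher of the two numbers available. Compound 2 (`COc1ncc(-c2ccc3c(c2)N(c2ccccc2)C(=O)CO3)cc1NS(=O)(=O)c1ccc(F)cc1`) gives 8870 nM as a lower number, with the gap beyond the scatter. Compound 3 (`COc1cccc(N2C(=O)COc3ccc(-c4ccc(O)cc4)cc32)c1`) reads > 40000 nM and this is a limit of the assay, not a number.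

Compound 4 (`Cc1ccc(N2C(=O)COc3ccc(-c4cnc(Cl)c(NS(=O)(=O)c5ccc(F)cc5)c4)cc32)cc1`) keeps the core of compound 1 and differs by one change: methyl in place of methoxy on an aromatic carbon with methyl in place of methoxy on an aromatic carbon, para to a large group. Within the data shown here, no pair of measured compounds shows this change, so the expectation has no direct precedent. In this assay no step beyond the scatter is expected, and the reference stays compound 1 at 36000 nM in either direction. The estimated step of a 1.3-fold lower number from compound 1 to compound 4 (0.11 log units; within the scatter) is accordingly small. A reading that reaches only a limit remains possible. Compound 4 is expected at 28000 nM with an estimated range from 12000 nM to 40000 nM for the measurement.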

Compound 4, half-maximal inhibitory concentration: 32600 nM
Estimate against measurement, compound 4: 1.2-fold (0.07 log units) below; low and high end bracket the measured number.
By their numbers in this assay, from the lowest: compound 2; then compounds 4 and 1 (each within the scatter of the next). At a limit, above all of these: compound 3.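

In this assay, among these compounds, the change from 4-methoxyphenyl to 4-methylphenyl gives a 1.1-fold lower number from compound 1 to compound 4 (0.04 log units; within the scatter), the first step between compounds that differ in one place. On this aromatic carbon, para to a large group, methoxy and its hydrogen-bond acceptor can therefore be replaced by methyl without a step beyond the scatter, at least on the core of compound 1. Compound 3 remains at a limit, not a number: the limit of > 40000 nM in this assay, at which 1 of the 4 values shown sits.

Methoxy and methyl are the only groups compared at this place on the shared core, so the effect of an amine, a carboxylic acid or a longer chain there stays open. Going by these compounds, whether the same change would also stay within the scatter on any other background also stays open.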